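The source may report more compounds than this note shows. Statements on the series, on what has been measured and on what is new or still open speak of the compounds shown alone.

The series shares one core, seen in compound 1 `O=c1ccoc2cc(OCc3cn(Cc4ccc(F)cc4)nn3)ccc12`. In a functional assay on SGC-7901 cells (Homo sapiens) for cytotoxicity, read by MTT assay, with a stated time of 48 h (on this read-out higher numbers stand for weaker inhibition and lower numbers for stronger inhibition), compound 1 gives > 100000 nM, which is a limit of the assay and not a number. Compound 2 `O=c1ccoc2cc(OCc3cn(Cc4cccc([N+](=O)[O-])c4)nn3)ccc12` carries 3-nitrophenyl in place of 4-fluorophenyl on a saturated chain carbon bound to an aromatic nitrogen. In this assay compound 2 gives > 100000 nM, again a limit rather than a number. Compound 3 `O=c1ccoc2cc(OCc3cn(Cc4ccccc4F)nn3)ccc12` carries 2-fluorophenyl at the same place. In this assay compound 3 gives > 100000 nM, also a limit. Compound 3 thus stands where the other two stand: all three share (the limit of > 100000 nM in this assay, at which 3 of the 3 values shown sit), and the steps a step that the two limits leave unreadable from compound 1 to compound 2, a step that the two limits leave unreadable from compound 1 to compound 3 and a step that the two limits leave unreadable from compound 2 to compound 3 cannot be sized.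

Within the data shown here, compound 4 `COc1ccc(Cn2cc(COc3ccc4c(=O)ccoc4c3)nn2)cc1` is not yet measured. 4-methoxyphenyl in place of 2-fluorophenyl on a saturated chain carbon bound to an aromatic nitrogen None of the measured steps can be read, so they give no size or direction for this change in this assay; they show only that three different groups at this place all left the limit untouched. Compound 4 is accordingly expected to stand at the limit as well, with the expected step that the limit leaves unreadable from compound 3 to compound 4 not readable beyond the scatter. For compound 4 the estimate is 150000 nM, within 50000 nM to 1000000 nM, and most likely reported as a limit only.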

Compound 4, half-maximal inhibitory concentration: > 100000 nM
Compound 4: a limit, no number; the forecaster's own chance of this, stated with the estimate: 85%; the middle value lies beyond the limit too.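

Compound 4 gives only a limit in this assay, so its steps to compound 1, compound 2 and compound 3 cannot be read and no new step can be sized: the limit of > 100000 nM in this assay, at which 4 of the 4 values shown sit.

The compounds shown leave open whether any group at this place on the shared core gives a readable number in this assay, and how far these four compounds lie apart.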